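Swapping the furan for a thiophene on the shared core

The source may report more compounds than this note shows. Statements on the series, on what has been measured and on what is new or still open speak of the compounds shown alone.

Compound 1: `CC1=C(C(=O)OC(C)C)C(c2ccsc2)N/C(=N/C#N)N1`, 647 nM
Compound 2: `CC1=C(C(=O)OC(C)C)C(c2ccco2)N/C(=N/C#N)N1`, 24.3 nM

Both compounds were tested in an assay on HEK293 cells for displacement of a labelled ligand from adenosine receptor A2b (Homo sapiens), with a stated time of 30 min (a lower number here means a stronger inhibitor, a higher number a weaker inhibitor), and they share one core, differing only in the aromatic ring attached to a saturated ring carbon. Compound 2 stands at the lower of the two numbers: the step from the thiophen-3-yl of compound 1 to the furan-2-yl of compound 2 gave a 27-fold lower number from compound 1 to compound 2 (1.43 log units; beyond the scatter).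

Compound 3 is `CC1=C(C(=O)OC(C)C)C(c2cccs2)N/C(=N/C#N)N1`, not yet measured. It differs from compound 2 by thiophen-2-yl in place of furan-2-yl on a saturated ring carbon. Going by the values given here, no measured pair shows exactly this exchange. Among the compounds with values here, the one measured step bears on it only in part: it changed both the ring atom and the point of attachment at once, and was large. Compound 3 keeps the attachment point of compound 2 but takes the sulfur of compound 1, so the number is expected to move back toward compound 1, without reaching it. The estimated step in this assay from compound 2 to compound 3 is a 4.1-fold higher number from compound 2 to compound 3 (0.61 log units; beyond the scatter). Compound 3 is therefore expected to give about 100 nM, in a range from 30 nM to 400 nM.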

Compound 3, inhibition constant: 349 nM
Estimate against measurement, compound 3: 3.5-fold (0.54 log units) below, within the range that was stated.
By their numbers in this assay, from the lowest: compound 2; then compounds 3 and 1 (each within the scatter of the next).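

In this assay, exchanging furan-2-yl for thiophen-2-yl while keeping the point of attachment gave a 14-fold higher number from compound 2 to compound 3 (1.16 log units; beyond the scatter), so at this saturated ring carbon the change of ring atom from oxygen to sulfur alone makes a large difference. Moving the attachment point within the thiophene gave a 1.9-fold lower number from compound 1 to compound 3 (0.27 log units; within the scatter), and this step lies within the scatter, so thiophen-2-yl and thiophen-3-yl cannot be told apart here. Among these three compounds, then, the furan-2-yl of compound 2 stands apart from both thiophenes, and the large step seen earlier is matched by the exchange of ring atom, while the change of attachment point on the thiophene leaves no step beyond the scatter.

The compounds shown leave open whether a furan-3-yl group would sit with furan-2-yl or with the thiophenes, and how a six-membered phenyl ring or a simple chain such as n-propyl would fare on the same carbon. Nothing available here accounts for the gap between the furan and the thiophenes.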